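The source may hold more compounds than are shown below. What is called first, only, known or untested is meant among the compounds shown, and "the series" means these compounds.

For the measured compounds named here, compound 2 `COc1cc(N/C=C\C(=O)c2cn(-c3ccccc3)nc2-c2ccc(F)cc2)cc(OC)c1OC` holds the lower of the two numbers so far, though the gap to compound 1 is within the scatter: in a functional assay on HT-29 cells (Homo sapiens) for antiproliferative activity, read by MTT assay, with a stated time of 48 h (on this read-out higher numbers stand for weaker inhibition and lower numbers for stronger inhibition), compound 2 gives 7770 nM, while compound 1 `COc1cc(N/C=C\C(=O)c2cn(-c3ccccc3)nc2-c2ccccc2)cc(OC)c1OC` gives 9800 nM. Going by the values given here, the single measured step, a 1.3-fold lower number from compound 1 to compound 2 (0.10 log units; within the scatter), was small. Compound 3 `COc1cc(N/C=C\C(=O)c2cn(-c3ccccc3)nc2-c2ccc(Cl)cc2)cc(OC)c1OC` differs from compound 2 by chloro in place of fluoro on an aromatic carbon. Among the compounds with values here, only that one halogen step bears on this change, and since it stayed within the scatter, no shift beyond the scatter is expected here either. The expected step is a 1.2-fold lower number from compound 2 to compound 3 (0.08 log units; within the scatter). For compound 3 in this assay the estimate is 6500 nM, expected between 2500 nM and 16000 nM.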

Compound 3, half-maximal inhibitory concentration: 12700 nM
The estimate for compound 3 lay 2.0-fold (0.29 log units) below the measured number, within the range that was stated.
By their numbers in this assay, from the lowest: compounds 2, 1 and 3 (each within the scatter of the next).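

On the six-membered aromatic ring, at the place para to a large group, swapping one halogen for the other gives a 1.6-fold higher number from compound 2 to compound 3 (0.21 log units; within the scatter), and chloro in place of hydrogen gives a 1.3-fold higher number from compound 1 to compound 3 (0.11 log units; within the scatter). Hydrogen, fluoro and chloro at this place therefore all stay within the scatter of one another, so the halogens show no trend here. Nothing measured explains this result. Still open, on these data alone, is whether an amine or a carboxylic acid at this place would move the number beyond the scatter, and whether changes elsewhere on the shared core would do so.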